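Branching the alkoxy chain on the shared core

A few compounds are considered here, and "the series" means these few. Any claim that something is new, unique, unknown or untested is made for them only; others in the source may bear on it.

Measured in a functional assay on cells (T-cell, Homo sapiens) for inhibition; a higher number here means a weaker inhibitor, a lower number a stronger inhibitor:
compound 1 `COc1ccc(-c2cnc3nc(N)nc(N4CCN(C(=O)NCc5ccc(F)cc5)CC4)c3n2)cc1OC` gives 37 nM
compound 2 `CCOc1nc(N)nc2ncc(-c3ccc(F)c(F)c3)nc12` is reported only as a limit of this assay, > 10000 nM

Compound 2 stands at the limit of this assay; no number is known for it, only (the limit of > 10000 nM in this assay, at which 1 of the 2 values shown sits). For the measured compounds named here, compound 1 is the only compound of the pair with a measured number, and no step between two measured compounds is available, so the size of a single structural change cannot be read from the data so far.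

Compound 3 `CC(C)Oc1nc(N)nc2ncc(-c3ccc(F)c(F)c3)nc12` differs from compound 2 by methyl in place of hydrogen on a saturated chain carbon bound to an oxygen on an aromatic ring and a saturated chain carbon. With compound 2 sitting at the limit, the step from compound 2 to compound 3 is expected to be none beyond the scatter, a step that the limit leaves unreadable from compound 2 to compound 3. Compound 3 is therefore expected most likely to return only a limit again in this assay, estimated at 15000 nM with a range of 4000 nM to 60000 nM.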

Compound 3, half-maximal inhibitory concentration: 10000 nM
Estimate against measurement, compound 3: 1.5-fold (0.18 log units) above, and the stated range covers the measured number.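

In this assay, for the compounds shown here, compound 3 gives 10000 nM, a measured number, so the isopropoxy group provides the first value for a small alkoxy chain on the shared core. Replacing hydrogen with methyl on the saturated chain carbon, ethoxy to isopropoxy, gives a number no higher from compound 2 to compound 3 (the limit leaves the size open). The branch therefore brings no readable gain or loss, and the size of the step stays open because compound 2 is reported only as a limit: the limit of > 10000 nM in this assay, at which 1 of the 3 values shown sits.

On these data alone, whether further branching, as in a tert-butoxy group, or a longer chain on the same oxygen would lower the number in this assay remains open. Also open, as far as these compounds go, is whether an amine in place of the alkoxy group would do so on this core.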